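The compounds below may be only part of what the source reports. "The series", "measured", "known", "first", "only" and "open" are said of these compounds alone.

Compound 1 `CCOC(=O)C(C)C(O)(c1ccc(OC)c(OC)c1OC)c1cccc2ccccc12` gives a limit of > 20000 nM in a functional assay on MCF7 cells (Homo sapiens) for inhibition, read by sulforhodamine B assay, with a stated time of 48 h; a lower number here means a stronger inhibitor, a higher number a weaker inhibitor.
Compound 2 `COc1cc(COC(c2ccc(OC)c(OC)c2OC)c2cccc3ccccc23)cc(OC)c1` gives a limit of > 20000 nM in this assay.
Compound 3 `COc1ccc(/C(=N/O)c2cccc3ccccc23)c(OC)c1OC` gives a limit of > 20000 nM in this assay.

None of the three measured compounds returns a number in this assay; each is reported only as a limit of the assay. Compound 2 therefore stands at the limit of > 20000 nM in this assay, at which 3 of the 3 values shown sit, with no measured value to place it above or below its two companions. The three structures share the same core of compound 2, and what is known of them so far is only that all of them sit at the limit.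

Compound 4 `COC(=O)c1ccc(COC(c2ccc(OC)c(OC)c2OC)c2cccc3ccccc23)cc1` has not yet been measured. It differs from compound 2 in one place, (4-(methoxycarbonyl)phenyl in place of 3,5-dimethoxyphenyl on a saturated chain carbon bound to an oxygen on a saturated carbon). Within the data shown here, no step between two measured compounds is available to show how such a change acts here, and with compound 2 itself at a limit, no direction can be read from the numbers. The expectation for compound 4 is therefore that the step that the limit leaves unreadable from compound 2 to compound 4 is none beyond the usual scatter, and that the assay most likely reports a limit again. On that basis, compound 4 is estimated at 30000 nM, in a range from 12000 nM to 100000 nM.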

Compound 4, half-maximal inhibitory concentration: > 20000 nM
Compound 4 ended at the assay's limit (the forecaster's own chance of this, stated with the estimate: 80%); the middle value lies beyond the limit too.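

Compound 2 and compound 4 both stand only at a limit of the assay, so no step between them can be read, and the picture remains unchanged: the limit of > 20000 nM in this assay, at which 4 of the 4 values shown sit.

The compounds shown leave open whether any change to the shared core would yield a measured value in this assay, and how far any such change would carry.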